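Lengthening the amine substituent on a hydroxyquinoline carboxamide

This account rests on a few compounds, and the source may have more. Where it says the series, first, only, none or still open, it means among the compounds named here.

Measured compounds:
compound 1, `O=C(NCc1ccc(F)cc1)c1nc(Br)c2cccnc2c1NCCCNc1c(C(=O)NCc2ccc(F)cc2)nc(Br)c2cccnc12`, > 20000 nM
compound 2, `C[C@@H](CO)Nc1nc(C(=O)NCc2ccc(F)cc2)c(O)c2ncccc12`, "not determined" (no result reported)
compound 3, `CS(=O)(=O)NCCCCCCN(c1nc(C(=O)NCc2ccc(F)cc2)c(O)c2ncccc12)S(C)(=O)=O`, 4000 nM

The three compounds were tested in a functional assay on HCT-116 cells (Homo sapiens) for cytotoxicity, read by MTT assay, with a stated time of 72 h; on this read-out lower numbers stand for stronger inhibition and higher numbers for weaker inhibition. Compound 1 is a dimer of two cores joined through a diamine linker, and its value there is a limit of the assay, > 20000 nM, not a number. Compound 3 carries a six-carbon chain bearing two methanesulfonyl groups on its ring nitrogen and gives 4000 nM. Compound 2 has no number in this assay; its result is recorded as "not determined" (no result reported), so it cannot be placed among the values.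

The step leads from compound 2 to compound 4, `O=CNCCCCCCNc1nc(C(=O)NCc2ccc(F)cc2)c(O)c2ncccc12`. The change is 6-(formylamino)hexyl in place of 1-(hydroxymethyl)ethyl on a nitrogen on an aromatic ring. With no number for compound 2, the size and direction of the step cannot be taken from it. Among the compounds with values here, the only guide is compound 3, whose hexyl chain and amide-like terminal group resemble those of compound 4. In this assay compound 3 gives 4000 nM. Compound 4 is therefore expected to give about 5000 nM, within a range of 1500 nM to 20000 nM.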

Compound 4, half-maximal inhibitory concentration: 6000 nM
For compound 4 the middle estimate is 1.2-fold (0.08 log units) below the measured one, within the range that was stated.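

Within the data shown here, no step from compound 2 to compound 4 can be read: compound 2 has no number in this assay, while compound 4 gives 6000 nM there. The compounds shown leave open how 6-(formylamino)hexyl compares with 1-(hydroxymethyl)ethyl on that nitrogen when nothing else changes.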